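Swapping a Furan for a Thiophene on a Saturated Carbon

The source may report more compounds than this note shows. Statements on the series, on what has been measured and on what is new or still open speak of the compounds shown alone.

Compound 1 `COC(=O)C1=C(C)NC(=O)NC1c1cccs1` gives 6% in an assay on membranes from CHO cells for displacement of a labelled ligand from adenosine receptor A1 (Homo sapiens), read by scintillation counting, with a stated time of 60 min, tested at 1 uM; on this read-out higher numbers stand for more inhibition at the one concentration tested (going by the name of the read-out) and lower numbers for less inhibition.
Compound 2 `CC1=C(C(=O)C2CC2)C(c2ccco2)NC(=O)N1` gives 2% in this assay.
Compound 3 `CC1=C(C(=O)C2CC2)C(c2ccoc2)NC(=O)N1` gives 1% in this assay.

Compound 3 has the lowest of the three numbers, but its gaps to compound 2 and to compound 1 both lie within the scatter, so the three cannot be told apart. Compound 4 `CC1=C(C(=O)C2CC2)C(c2cccs2)NC(=O)N1` carries the change (thiophen-2-yl in place of furan-3-yl on a saturated ring carbon). Among the compounds with values here, the one measured step that bears on exchanging the aromatic group on this saturated ring carbon is a number 1 percentage points lower from compound 2 to compound 3 (within the scatter), which stays within the scatter. Compound 1 also bears a thiophen-2-yl group, on a different core, and its number is likewise low. A step of a number 2 percentage points higher from compound 3 to compound 4 (within the scatter) is therefore expected, none beyond the scatter. Compound 4 is estimated at 3%, in the range 0% to 12%.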

Compound 4, a percentage reported as inhibition, at one concentration (the size of the read-out at that concentration, not a potency): 1%
Estimate against measurement, compound 4: 2 percentage points above; low and high end bracket the measured number.
By their numbers in this assay, from the lowest: compounds 3, 4, 2 and 1 (each within the scatter of the next).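

On the saturated ring carbon, thiophen-2-yl in place of furan-3-yl gives no change at the digits printed from compound 3 to compound 4 (within the scatter) in this assay, and thiophen-2-yl in place of furan-2-yl gives a number 1 percentage points lower from compound 2 to compound 4 (within the scatter), so a sulfur-containing aromatic ring reads the same here as either furan. Within the data shown here, on the carbonyl carbon, a place no earlier step touched, cyclopropyl in place of methoxy gives a number 5 percentage points lower from compound 1 to compound 4 (within the scatter).

Still open, going by these compounds, is whether an amine on this ring carbon, or a longer chain on the carbonyl carbon, would move the number beyond the scatter. No measurement offered here accounts for these numbers.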